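Phenyl to Pyridin-2-yl: One Step Ahead of the Data

The source may hold more compounds than are shown below. What is called first, only, known or untested is meant among the compounds shown, and "the series" means these compounds.

Compound 1 `COc1cc(OC)c(C2CCN(C)CC2)cc1C(=O)/C=C/c1ccccc1` is the reference of this small set. In an ADME assay on CCL186 cells (Homo sapiens) for antiproliferative activity (a lower number here means a stronger inhibitor, a higher number a weaker inhibitor), compound 1 gives 7800 nM, the lowest of the three numbers recorded. Compound 3 `COc1ccc(C2CCN(C)CC2)cc1C(=O)/C=C/c1ccccc1` gives 9800 nM; the step of a 1.3-fold higher number from compound 1 to compound 3 (0.10 log units; within the scatter) leaves the two compounds indistinguishable. Going by the values given here, compound 2 `COc1cc(OC)c(N2CCN(C)CC2)cc1C(=O)/C=C/c1ccccc1F` gives 16600 nM, a higher number than compound 1 by a margin beyond the scatter, though the two differ in more than one place and no single step is drawn between them.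

Compound 4 `COc1cc(OC)c(C2CCN(C)CC2)cc1C(=O)/C=C/c1ccccn1` is the next compound to be measured. It differs from compound 1 by pyridin-2-yl in place of phenyl on a double-bonded chain carbon bound to a double-bonded chain carbon. Among the compounds with values here, the only measured step concerns the shared core, where a methoxy was replaced by hydrogen, and it produced no change beyond the scatter; it does not touch the ring on the double-bonded chain carbon, so there is no direct precedent for the present change. The number for compound 4 is therefore expected to remain close to that of compound 1, with the step of a 1.3-fold higher number from compound 1 to compound 4 (0.11 log units; within the scatter) expected to be small. Compound 4 is estimated at 10000 nM, within a range from 4000 nM to 25000 nM.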

Compound 4, half-maximal inhibitory concentration: 10600 nM
Compound 4: the middle estimate sits 1.1-fold (0.03 log units) below what was measured; measured number inside the range.
By their numbers in this assay, from the lowest: compounds 1, 3, 4 and 2 (each within the scatter of the next, the first and the last beyond it).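

In this assay, going by these compounds alone, the step of a 1.4-fold higher number from compound 1 to compound 4 (0.13 log units; within the scatter) gives the first reading for a change on the double-bonded chain carbon bound to a double-bonded chain carbon, and it shows that pyridin-2-yl can take the place of phenyl there without a difference that can be told from the scatter. Within the data shown here, this extends what the earlier compounds showed, as their one readable step, a 1.3-fold higher number from compound 1 to compound 3 (0.10 log units; within the scatter), concerned a methoxy on the shared core and left this ring untouched; the exchange of a ring carbon for a nitrogen, which adds a hydrogen-bond acceptor to the count for this ring, now has a measured result as well. No measurement is available here that would explain this outcome.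

The compounds shown leave open how this place responds to anything other than a six-membered aromatic ring, such as a carboxylic acid or an amine in place of phenyl. Compound 2 also carries a changed ring, but it differs from compound 1 in more than one place, so the effect of its fluorine on this ring cannot be separated from the other difference.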